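Compound 3: pyridin-2-yl on the amide-type ring nitrogen

A few compounds are considered here, and "the series" means these few. Any claim that something is new, unique, unknown or untested is made for them only; others in the source may bear on it.

Compound 1 `Cc1cccc(N2C(=O)CSC2c2cccc(C(=O)NCCCCc3ccccc3)c2)c1`: 10000 nM
Compound 2 `O=C(NCCCCc1ccccc1)c1cccc(C2SCC(=O)N2c2cccc(-c3c[nH]nn3)c2)c1`: 20000 nM

In a physicochemical assay for solubility, read by turbidimetry, measured as kinetic solubility, at pH 6.8 (a lower number here means a less soluble compound, a higher number a more soluble compound), compound 2 gives 20000 nM, which cannot be told apart from compound 1 at 10000 nM once the usual scatter is allowed for. Compound 3 `O=C(NCCCCc1ccccc1)c1cccc(C2SCC(=O)N2c2ccccn2)c1` has not yet been measured. Its difference from compound 2 is a group of 6 heavy atoms (5 carbon, 1 nitrogen; one six-membered aromatic ring with 1 hetero atom) in place of a group of 11 heavy atoms (8 carbon, 3 nitrogen; one five-membered aromatic ring with 3 hetero atoms, one six-membered aromatic ring of carbon only), on an amide-type nitrogen in a ring. The new group, pyridin-2-yl, sits on an amide-type nitrogen in a ring, where it replaces the whole of the larger group.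

Among the compounds with values here, only one measured step bears on this change. In a 2.0-fold higher number from compound 1 to compound 2 (0.30 log units; within the scatter), 1H-1,2,3-triazol-4-yl stands in place of methyl on an aromatic carbon, and that step stays within the scatter. Within the data shown here, no measured step replaces the whole group on the nitrogen, so this evidence is indirect. Among the measured compounds shown here, with a 2.0-fold higher number from compound 1 to compound 2 (0.30 log units; within the scatter) as the only guide, no clear move in either direction is expected. The estimate means a 1.3-fold lower number from compound 2 to compound 3 (0.12 log units; within the scatter), an expected step that stays within the scatter. In this assay compound 3 is expected to give 15000 nM, with an estimated range from 6000 nM to 40000 nM.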

Compound 3, solubility: 20000 nM
Compound 3: the middle estimate sits 1.3-fold (0.12 log units) below what was measured, and the stated range covers the measured number.
By their numbers in this assay, from the lowest: compounds 1, 2 and 3 (each within the scatter of the next).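

In this assay, within the data shown here, the earlier compounds differed only on an aromatic carbon of the group held by the amide-type nitrogen in a ring, whereas compound 3 exchanges that whole group. Pyridin-2-yl, with 6 heavy atoms and 0 hydrogen-bond donors, takes the place of a group of 11 heavy atoms with 1 hydrogen-bond donor, and this gives no change at the digits printed from compound 2 to compound 3 (within the scatter); in place of 3-methylphenyl the same group gives a 2.0-fold higher number from compound 1 to compound 3 (0.30 log units; within the scatter), so the three groups on this nitrogen cannot be told apart here, despite their differences in size and ring type. No measurement is at hand that would explain this flat result.

The compounds shown keep the rest of the molecule constant, so they leave open whether changing the phenylbutyl chain on the amide, for instance by adding a carboxylic acid to it or replacing it with a shorter chain, would take the number beyond the scatter. They also leave open whether a piperazine or a morpholine attached to the pyridine ring on the amide-type nitrogen would do so.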